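Removing the carbamoyl group from compound 1

The compounds below may be only part of what the source reports. "The series", "measured", "known", "first", "only" and "open" are said of these compounds alone.

Three compounds have been measured in an assay for inhibition of MAP kinase-interacting serine/threonine-protein kinase 1 (Homo sapiens), read by luminescence and ADP-Glo, with a stated time of 2 h; on this read-out lower numbers stand for stronger inhibition and higher numbers for weaker inhibition:
compound 1 `NC(=O)c1cccc(Cn2cc(-c3ccc4cn[nH]c4c3)ccc2=O)c1` gives 388 nM
compound 2 `Nc1n[nH]c2cc(-c3ccc(=O)n(Cc4ccccc4F)c3)ccc12` gives 12 nM
compound 3 `Nc1n[nH]c2cc(-c3ccc(=O)n(Cc4cccc(Cl)c4)c3)ccc12` gives 11 nM

Compound 1 carries the highest number of the three, so it is the weakest inhibitor here; compound 2 and compound 3 both sit far below it, well beyond the scatter, and the two of them lie within the scatter of each other.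

Compound 4 `O=c1ccc(-c2ccc3cn[nH]c3c2)cn1Cc1ccccc1` differs from compound 1 in one place: hydrogen in place of carbamoyl on an aromatic carbon. Among the compounds with values here, no measured pair shows this particular change. Within the data shown here, the single step on record, a 1.1-fold lower number from compound 2 to compound 3 (0.04 log units; within the scatter), exchanges one halogenated side ring for another and stays within the scatter, but it concerns compounds whose shared core differs from that of compound 1 by an amino group, so it only shows that a swap on that side ring need not move the number much. Whether losing the carbamoyl matters is simply not covered by the data.

With nothing pointing strongly either way, compound 4 is expected to stay near compound 1 in this assay, with perhaps a modestly higher number, that is a 1.3-fold higher number from compound 1 to compound 4 (0.11 log units; within the scatter). The estimate for compound 4 is 500 nM, with a range from 150 nM to 1600 nM.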

Compound 4, half-maximal inhibitory concentration: 315 nM
For compound 4 the middle estimate is 1.6-fold (0.20 log units) above the measured one; the range from low to high includes it.
By their numbers in this assay, from the lowest: compounds 3 and 2 (each within the scatter of the next); then compounds 4 and 1 (each within the scatter of the next).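

In this assay, hydrogen in place of carbamoyl on this aromatic carbon gives a 1.2-fold lower number from compound 1 to compound 4 (0.09 log units; within the scatter), so at this place, on a six-membered aromatic ring of carbon only and meta to a large group, the number does not respond in any readable way to the loss of the carbamoyl group and its 3 heavy atoms. Within the data shown here, the earlier compounds could not show this: their only step exchanged one halogenated side ring for another on a core carrying an amino group, and it left the carbamoyl group out of the comparison altogether. No measured evidence is available to explain the result.

The compounds shown leave open whether a different group on this aromatic carbon, such as a carboxylic acid, a methoxy group or an aminomethyl group, would leave the number where it is or move it beyond the scatter. They also leave open whether removing a carbamoyl group would give an equally small step on the core that carries the amino group, since this one pair speaks only for the core of compound 1.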